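The source may hold more compounds than are shown below. What is called first, only, known or untested is meant among the compounds shown, and "the series" means these compounds.

Measured in an ADME assay on WI-38 cells (Homo sapiens) for cytotoxicity, read by MTT assay, with a stated time of 72 h; on this read-out higher numbers stand for weaker inhibition and lower numbers for stronger inhibition:
Compound 1 `O=C(CCc1cccc2c1B(O)OC2)Nc1ccccc1`: 30000 nM
Compound 2 `O=C(CCc1cccc2c1B(O)OC2)Nc1ccc(Cl)cc1`: > 100000 nM (a limit of the assay, not a number)
Compound 3 `O=C(CCc1cccc2c1B(O)OC2)Nc1ccc(Br)cc1`: 42000 nM

Within the data shown here, compound 1 has only one measured number to stand against, and the gap is a 1.4-fold higher number from compound 1 to compound 3 (0.15 log units; within the scatter). The only other result is the limit for compound 2, so an at least 3.3-fold higher number from compound 1 to compound 2 (0.52 log units; beyond the scatter) rests on (the limit of > 100000 nM in this assay, at which 1 of the 3 values shown sits).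

Compound 4 `COc1ccccc1NC(=O)CCc1cccc2c1B(O)OC2` differs from compound 1 by methoxy in place of hydrogen on an aromatic carbon. The nearest evidence comes from the two steps that also replace hydrogen on an aromatic carbon, though with chloro and bromo rather than methoxy. These steps do not agree in size: one is an at least 3.3-fold higher number from compound 1 to compound 2 (0.52 log units; beyond the scatter), the other 1.4-fold higher number from compound 1 to compound 3 (0.15 log units; within the scatter), and between them lies an at least 2.3-fold lower number from compound 2 to compound 3 (0.37 log units; beyond the scatter). Neither moves to a lower number, so a small move towards a higher number in this assay is expected, probably not beyond the scatter. The expected step is a 1.3-fold higher number from compound 1 to compound 4 (0.12 log units; within the scatter). For compound 4 the estimated value is 40000 nM, with an expected range from 15000 nM to 100000 nM.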

Compound 4, half-maximal inhibitory concentration: 1600 nM
Beside the measured number, compound 4's estimate is 25-fold (1.40 log units) above it, outside the stated range (below it).
By their numbers in this assay, from the lowest: compound 4; then compounds 1 and 3 (each within the scatter of the next). At a limit, above all of these: compound 2.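

In this assay, among these compounds, the methoxy in place of hydrogen on an aromatic carbon, ortho to a large group, gives a 19-fold lower number from compound 1 to compound 4 (1.27 log units; beyond the scatter), the first step in this set to reach a lower number beyond the scatter. The earlier chloro and bromo replacements of hydrogen on an aromatic carbon had produced no move to a lower number, so replacing hydrogen on this ring does not have one fixed outcome in this assay, and a single change to compound 1 can strengthen the inhibition read here substantially. Nothing in the data given accounts for the size of this step.

The compounds shown leave open whether the shift belongs to methoxy itself or to its place on the ring. An amine or an ethoxy group at that same place, or methoxy on another aromatic carbon, would separate these two readings.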